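Swapping a cyclopropyl for an isopropyl on a purine-like core

The compounds below may be only part of what the source reports. "The series", "measured", "known", "first", "only" and "open" are said of these compounds alone.

Four compounds share one core, measured in a functional assay on the whole organism for antagonist activity, with Rattus norvegicus as the target; a lower number here means that less compound is needed, a higher number that more compound is needed for the effect. Compound 1 `c1nc(NC2CC2)c2ncn(CC3CCC3)c2n1` gives 44 mg/kg. Compound 3 `c1nc(NC2CC2)c2ncn(C3CC3)c2n1` gives 20 mg/kg, the lowest of the two single numbers, with compound 1 nearest at a 2.2-fold lower number from compound 1 to compound 3 (0.34 log units; beyond the scatter). Compound 2 `CC(C1CC1)n1cnc2c(NC3CC3)ncnc21` gives 9 mg/kg; 25 mg/kg; > 25 mg/kg (3 entries) across several entries. Compound 4 `CC(C)n1cnc2c(NC3CC3)ncnc21` is unmeasured; its change from compound 3 is isopropyl in place of cyclopropyl on an aromatic nitrogen. Going by the values given here, no measured step alters this particular group, so no step bears directly on it; the spread of repeats for compound 2 the several entries of compound 2 in this assay, 9 mg/kg; 25 mg/kg; > 25 mg/kg (3 entries) only shows how loose such readings can be. The step of no change at the digits printed from compound 3 to compound 4 (within the scatter) is therefore expected to stay within the scatter. Compound 4 is estimated at 20 mg/kg, ranging from 7 mg/kg to 60 mg/kg.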

Compound 4, dose for half-maximal effect: 30 mg/kg
Compound 4: middle estimate off by 1.5-fold (0.18 log units), on the low side; low and high end bracket the measured number.
By their numbers in this assay, from the lowest: compounds 3, 4 and 1 (each within the scatter of the next, the first and the last beyond it).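

In this assay, opening the cyclopropyl ring to isopropyl on the aromatic nitrogen gives a 1.5-fold higher number from compound 3 to compound 4 (0.18 log units; within the scatter), so at this position the closed ring makes no readable difference. Isopropyl in place of cyclobutylmethyl gives a 1.5-fold lower number from compound 1 to compound 4 (0.17 log units; within the scatter), which leaves isopropyl not separable from either group, although those two groups differ from each other beyond the scatter. Compound 2 shows how widely repeats can run, its last entry being a limit of the assay and not a number: the several entries of compound 2 in this assay, 9 mg/kg; 25 mg/kg; > 25 mg/kg (3 entries)

From the compounds shown here alone, what an amine, a carboxylic acid or a longer chain on this aromatic nitrogen would do remains open.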